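Swapping Cyclopropyl for Dimethylpyrazolyl: Expected Lipophilicity

The source may report more compounds than this note shows. Statements on the series, on what has been measured and on what is new or still open speak of the compounds shown alone.

Compound 1 `CN1CCN(CCCS(=O)(=O)c2ccc3nc(NC(=O)NC(=O)c4cc(C5CC5)ccc4Cl)sc3c2)CC1` is the more lipophilic of the two measured compounds in a physicochemical assay for lipophilicity (a higher number here means a more lipophilic compound, a lower number a more polar compound), where compound 1 gives 2.9. Compound 2 `COCCNCCCS(=O)(=O)c1ccc2nc(NC(=O)NC(=O)c3ccccc3Cl)sc2c1` lies a gap beyond the usual scatter below it; in this assay compound 2 gives 1.3. Compound 3 `Cc1cc(C)n(-c2ccc(Cl)c(C(=O)NC(=O)Nc3nc4ccc(S(=O)(=O)CCCN5CCN(C)CC5)cc4s3)c2)n1` has not yet been measured. It differs from compound 1 in one place: 3,5-dimethyl-1H-pyrazol-1-yl in place of cyclopropyl on an aromatic carbon. Among the compounds with values here, no measured pair isolates this change, so only an expectation can be offered. The step of a number 0.40 log units lower from compound 1 to compound 3 (beyond the scatter) is expected to be a modest fall, possibly just beyond the scatter. Compound 3 is therefore estimated at 2.5, within a range from 1.9 to 3.1.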

Compound 3, distribution coefficient: 2.5
Estimate against measurement, compound 3: no gap at the digits printed; the range from low to high includes it.
By their numbers in this assay, from the lowest: compound 2; then compound 3; then compound 1.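

Within the data shown here, the first reading of this change at this position, on an aromatic carbon para to a chloro group, comes in this assay: 3,5-dimethyl-1H-pyrazol-1-yl in place of cyclopropyl gives a number 0.40 log units lower from compound 1 to compound 3 (beyond the scatter). The number thus falls even though the entering group has 7 heavy atoms against 3 and brings 2 hydrogen-bond acceptors. No evidence at hand accounts for the fall. Still open, going by these compounds, is how a pyrazolyl without its two methyl groups, or a morpholine, would read on this carbon. Also open, on these data alone, is whether the step holds on a different side chain.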